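This account rests on a few compounds, and the source may have more. Where it says the series, first, only, none or still open, it means among the compounds named here.

In a functional assay on the whole organism with Canis familiaris (Canis lupus familiaris) as the target (a lower number here means that less compound is needed, a higher number that more compound is needed for the effect), three compounds have been measured. Compound 1, with the structure `OC(CSc1[nH]cnc2ncnc1-2)CN1CCN(C(c2ccc(Br)cc2)c2ccc(Br)cc2)CC1`, gives 0.31 mg/kg. Compound 2, with the structure `OC(CSc1ncnc2[nH]cnc12)CN1CCN(C(c2ccc(F)cc2)c2ccc(F)cc2)CC1`, gives 0.15 mg/kg. Compound 3, with the structure `OC(CSc1[nH]cnc2ncnc1-2)CN1CCN(C(c2cccc(C(F)(F)F)c2)c2cccc(C(F)(F)F)c2)CC1`, gives 1.1 mg/kg. Among these, compound 2 stands at the lowest number of the three, and its nearest neighbour, compound 1, sits beyond the scatter above it, while compound 3 sits further still, also beyond the scatter.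

The compound that has not yet been measured is compound 4, with the structure `Nc1nc(SCC(O)CN2CCN(C(c3ccc(F)cc3)c3ccc(F)cc3)CC2)c2[nH]cnc2n1`. It differs from compound 2 in a single place: a group of 10 heavy atoms (5 carbon, 5 nitrogen; one five-membered aromatic ring with 2 hetero atoms, one six-membered aromatic ring with 2 hetero atoms) in place of a group of 9 heavy atoms (5 carbon, 4 nitrogen; one five-membered aromatic ring with 2 hetero atoms, one six-membered aromatic ring with 2 hetero atoms), on a sulfur. Among the compounds with values here, no pair of measured compounds shows this kind of change, so the effect of adding a hydrogen-bond donor and acceptor to the core is not known from the data.

Without a measured precedent, the step from compound 2 to compound 4 in this assay is expected to be small, probably none beyond the scatter, with the estimate centred close to the number for compound 2 and allowing drift in either direction. The expected change is a 1.3-fold higher number from compound 2 to compound 4 (0.12 log units; within the scatter). Compound 4 is therefore estimated at 0.2 mg/kg, with a range from 0.07 mg/kg to 0.6 mg/kg.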

Compound 4, dose for half-maximal effect: 0.85 mg/kg
For compound 4 the middle estimate is 4.3-fold (0.63 log units) below the measured one; measured number outside the range, above it.
By their numbers in this assay, from the lowest: compound 2; then compound 1; then compounds 4 and 3 (each within the scatter of the next).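

In this assay, putting the group of 10 heavy atoms in place of the group of 9 heavy atoms, on a sulfur whose other neighbour is a saturated chain carbon, gives a 5.7-fold higher number from compound 2 to compound 4 (0.75 log units; beyond the scatter). This is the only single-place step among the compounds shown, and it establishes that, with the rest of compound 2 unchanged, this exchange alone moves the number beyond the scatter, towards more compound being needed for the effect. The entering group carries 2 hydrogen-bond donors and 4 hydrogen-bond acceptors against 1 and 3 in the group it replaces, but no measurement at hand accounts for the step.

The compounds shown do not tell whether the same exchange would produce a step of similar size with the bromine-bearing aryl groups of compound 1 or the trifluoromethyl-bearing aryl groups of compound 3. They also leave open how a methyl group or a plain phenyl ring on the same sulfur would read in this assay, and so how far this position tolerates groups other than these two.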